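A few compounds are considered here, and "the series" means these few. Any claim that something is new, unique, unknown or untested is made for them only; others in the source may bear on it.

In a functional assay on BT-549 cells (Homo sapiens) for cytotoxicity, read by MTT assay, with a stated time of 48 h (on this read-out higher numbers stand for weaker inhibition and lower numbers for stronger inhibition), compound 1 (`CC(C)n1c(/C=C2/C(=O)Nc3ccc(F)cc32)nc2ccccc21`) gives 26700 nM. Compound 2 (`CCn1c(/C=C2/C(=O)Nc3ccc(C)cc32)nc2ccccc21`) is recorded at > 50000 nM, which is a limit of the assay and not a number. For the measured compounds named here, that entry is the only limit so far: the limit of > 50000 nM in this assay, at which 1 of the 3 values shown sits. From the compounds shown here alone, compound 3 (`Cn1c(/C=C2/C(=O)Nc3ccc([N+](=O)[O-])cc32)nc2ccccc21`) has no number to stand on, its entry being "not determined" (no result reported), so its place remains open.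

Compound 4 (`Cn1c(/C=C2/C(=O)Nc3ccc(Br)cc32)nc2ccccc21`) is still unmeasured. The change to follow is bromo in place of nitro on an aromatic carbon, in words bromo in place of nitro on an aromatic carbon.

Going by the values given here, with no number for compound 3, the step has no measured starting point and no measured step exists to serve as a guide. In this assay no step beyond the scatter is expected, in either direction, from the general level of the series. Among the compounds with values here, the only firm number available as an anchor is that of compound 1 at 26700 nM. For compound 4 the estimated value is 28000 nM, with an expected range from 10000 nM to 50000 nM.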

Compound 4, half-maximal inhibitory concentration: > 50000 nM
Compound 4: no number, only a limit (the forecaster's own chance of this, stated with the estimate: 35%); middle value at least 1.7-fold (0.25 log units) away from the limit.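

No step can be read between compound 3 and compound 4, as compound 3 has no number. Compound 4 stands at a limit and not a number: the limit of > 50000 nM in this assay, at which 2 of the 4 values shown sit. The compounds shown leave open how bromo and nitro on this aromatic carbon compare in this assay.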